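The source may report more compounds than this note shows. Statements on the series, on what has been measured and on what is new or still open speak of the compounds shown alone.

Values in a functional assay on HT cells (Homo sapiens) for antiproliferative activity, read by fluorescence, with a stated time of 72 h (a higher number here means a weaker inhibitor of growth, a lower number a stronger inhibitor of growth), so far:
- compound 1 `CC(C)c1n[nH]c2c(NCc3ccc(-c4ccccn4)cc3)nc(SC3CCCCC3O)nc12` gives 636 nM
- compound 2 `CC(C)c1n[nH]c2c(NCc3ccc(-c4ccccn4)cc3)nc(SCC(N)=O)nc12` gives 192 nM

Compound 2 holds the lower of the two numbers (192 nM), and the gap to compound 1 lies beyond the scatter. Compound 3 `CC(C)c1n[nH]c2c(NCc3ccc(-c4ccccn4)cc3)nc(SC[C@H](O)CN)nc12` differs from compound 2 in one place (2-amino-1-hydroxyethyl in place of carbamoyl on a saturated chain carbon bound to a sulfur), with 2-amino-1-hydroxyethyl in place of carbamoyl on a saturated chain carbon bound to a sulfur.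

Within the data shown here, only one measured step bears on this change: a 3.3-fold lower number from compound 1 to compound 2 (0.52 log units; beyond the scatter) with carbamoylmethyl in place of 2-hydroxycyclohexyl on a sulfur. That step is modest and beyond the scatter, but it involves a different pair of groups. Among the measured compounds shown here, no measured compound carries the amino group, so the data give no clear direction for the new change. The working expectation in this assay is therefore a step no larger than the measured one, and probably none beyond the scatter. The expected change is a 1.1-fold lower number from compound 2 to compound 3 (0.05 log units; within the scatter) on this reasoning. Compound 3 is estimated at 170 nM (expected range 60 nM to 500 nM).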

Compound 3, concentration for 50% growth inhibition: 63 nM
Compound 3: middle estimate off by 2.7-fold (0.43 log units), on the high side; the range from low to high includes it.
By their numbers in this assay, from the lowest: compound 3; then compound 2; then compound 1.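

In this assay, the sulfur substituent remains a productive place to vary: 2-amino-1-hydroxyethyl in place of carbamoyl on a saturated chain carbon bound to a sulfur gives a 3.0-fold lower number from compound 2 to compound 3 (0.48 log units; beyond the scatter), so the carbamoylmethyl group of compound 2 is not the best group seen here. Set against the ring-bearing substituent, 3-amino-2-hydroxypropyl in place of 2-hydroxycyclohexyl on a sulfur gives a 10-fold lower number from compound 1 to compound 3 (1.00 log units; beyond the scatter), which makes compound 3 the strongest inhibitor of growth of the three and shows that changes at this one place alone can span a wide range of values on the shared core. Nothing available explains either step.

The amino and hydroxyl groups enter together, so their separate contributions remain unresolved; a 3-aminopropyl chain without the hydroxyl and a 2,3-dihydroxypropyl chain without the amine would divide the step between them. From the compounds shown here alone, the role of the one defined stereocentre is also open, and the opposite stereoisomer of the 3-amino-2-hydroxypropyl chain, like a longer aminoalkyl chain, would test how specific the present arrangement is.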